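This account rests on a few compounds, and the source may have more. Where it says the series, first, only, none or still open, it means among the compounds named here.

Measured in a functional assay on MCF7 cells (Homo sapiens) for cytotoxicity, read by CCK-8 assay, with a stated time of 48 h; on this read-out lower numbers stand for stronger inhibition and higher numbers for weaker inhibition:
Compound 1 `O=c1oc2ccccc2c(Cl)c1/C=N/c1ccc(S(=O)(=O)Nc2nccs2)cc1`: 160 nM
Compound 2 `N=C(N)NS(=O)(=O)c1ccc(/N=C/c2c(Cl)c3ccccc3oc2=O)cc1`: 58 nM
Compound 3 `CC(C)(C)c1cc(C(C)(C)C)c2oc(=O)c(/C=N/c3ccc(S(=O)(=O)Nc4nccs4)cc3)c(Cl)c2c1`: 12 nM

Compound 1 and compound 2 differ in one place, (a group of 3 heavy atoms (1 carbon, 2 nitrogen; no ring) in place of a group of 5 heavy atoms (3 carbon, 1 nitrogen, 1 sulfur; one five-membered aromatic ring with 2 hetero atoms), on a sulfonamide nitrogen). That change gave a 2.8-fold lower number from compound 1 to compound 2 (0.44 log units; beyond the scatter) in this assay. Compound 3 carries a different core; how its core differs from that of compound 1 is not broken down here, but compound 3 gives the lowest number of the three in this assay. Compound 4 `CC(C)(C)c1cc(C(C)(C)C)c2oc(=O)c(/C=N/c3ccc(S(=O)(=O)NC(=N)N)cc3)c(Cl)c2c1` is not yet measured. It stands to compound 3 as compound 2 stands to compound 1: the difference is a group of 3 heavy atoms (1 carbon, 2 nitrogen; no ring) in place of a group of 5 heavy atoms (3 carbon, 1 nitrogen, 1 sulfur; one five-membered aromatic ring with 2 hetero atoms), on a sulfonamide nitrogen, and since the two place lines agree word for word, this is the same change. Carried over from compound 1 and compound 2, the step from compound 3 to compound 4 is expected to be a 2.4-fold lower number from compound 3 to compound 4 (0.38 log units; beyond the scatter), resting on a 2.8-fold lower number from compound 1 to compound 2 (0.44 log units; beyond the scatter). Compound 4 is therefore estimated at 5 nM in this assay, with a range of 2 nM to 15 nM expected.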

Compound 4, half-maximal inhibitory concentration: 18 nM
Estimate against measurement, compound 4: 3.6-fold (0.56 log units) below; measured number outside the range, above it.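

In this assay, putting the group of compound 4 on the sulfonamide nitrogen in place of 1,3-thiazol-2-yl gave a 1.5-fold higher number from compound 3 to compound 4 (0.18 log units; within the scatter). The step seen on the core of compound 1 therefore did not carry over to the core of compound 3: the same change on two cores in this assay, a 2.8-fold lower number (0.44 log units; beyond the scatter) from compound 1 to compound 2 and a 1.5-fold higher number (0.18 log units; within the scatter) from compound 3 to compound 4, 4.1-fold (0.62 log units) apart, beyond the scatter of two such steps This shows that the same change cannot be assumed to give the same step on both of these cores, but two pairs do not show what sets the steps apart or how the change would behave on a third core.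

The compounds shown leave open whether other groups on the sulfonamide nitrogen, such as pyridin-2-yl or acetyl, would also give different steps on the two cores.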